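The source may report more compounds than this note shows. Statements on the series, on what has been measured and on what is new or still open speak of the compounds shown alone.

The measured compounds in a functional assay on HEK293 cells for antagonist activity at transient receptor potential cation channel subfamily V member 1 (Rattus norvegicus), read by calcium flux; on this read-out lower numbers stand for stronger inhibition and higher numbers for weaker inhibition:
compound 1, `CN(c1nc2c(Nc3ccc(C(F)(F)F)cc3)ncnc2s1)c1c(Cl)cccc1Cl`, 540 nM
compound 2, `CSc1ccccc1Nc1nc2c(Nc3ccc(C(F)(F)F)cc3)ncnc2s1`, 26 nM
compound 3, `CS(=O)(=O)c1ccc(Nc2ncnc3sc(Nc4c(Cl)cccc4Cl)nc23)cc1`, 3 nM

On these three numbers compound 2 stands second highest in this assay: compound 3 gives a lower number and compound 1 a higher one, and both gaps lie beyond the scatter. Compound 4, `OCc1cc(Cl)c(Nc2nc3c(Nc4ccc(C(F)(F)F)cc4)ncnc3s2)c(Cl)c1`, is not yet measured and differs from compound 2 in one place: 2,6-dichloro-4-(hydroxymethyl)phenyl in place of 2-(methylsulfanyl)phenyl on a nitrogen on an aromatic ring.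

Going by the values given here, only one measured step is available, a 21-fold lower number from compound 1 to compound 2 (1.32 log units; beyond the scatter), and it changed two things at once, the ring and the methyl on the nitrogen, so it does not isolate the ring swap that separates compound 2 from compound 4. Compound 3 carries a (2,6-dichlorophenyl)amino group on the same nitrogen and gives 3 nM in this assay, but it also differs from compound 2 elsewhere, so its value only hints that such a ring sits well with low numbers. Taken together, a small step toward lower numbers is expected for compound 4, a 1.7-fold lower number from compound 2 to compound 4 (0.24 log units; within the scatter), with little beyond the scatter assured. The estimate for compound 4 in this assay is 15 nM, within 4 nM to 60 nM.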

Compound 4, half-maximal inhibitory concentration: 0.5 nM
Beside the measured number, compound 4's estimate is 30-fold (1.48 log units) above it; the measured number lies below the stated range.
By their numbers in this assay, from the lowest: compound 4; then compound 3; then compound 2; then compound 1.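

Exchanging 2-(methylsulfanyl)phenyl for 2,6-dichloro-4-(hydroxymethyl)phenyl on the nitrogen, with the rest of the molecule unchanged, gives a 52-fold lower number from compound 2 to compound 4 (1.72 log units; beyond the scatter) in this assay. The earlier step from compound 1 to compound 2 altered the ring and the methyl on the nitrogen together, whereas here the nitrogen keeps its hydrogen and both groups are six-membered aromatic rings of carbon only, which leaves what the ring carries as the one thing that differs. This position therefore responds strongly to the groups on that ring, yet nothing measured here explains why the number falls so far.

The step removes the methylsulfanyl and brings in two chlorines and a hydroxymethyl all at once, and the compounds shown do not divide its size among these groups. Going by these compounds, whether an aminomethyl group or a carboxylic acid in place of the hydroxymethyl would keep the number this low also stays open.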